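Indole–oxazole series: ring-nitrogen methylation of compound 2

The source may hold more compounds than are shown below. What is called first, only, known or untested is meant among the compounds shown, and "the series" means these compounds.

Two compounds of the shared core carry numbers in a functional assay on MDA-MB-231 cells (Homo sapiens) for cytotoxicity, read by MTT assay, with a stated time of 48 h; on this read-out lower numbers stand for stronger inhibition and higher numbers for weaker inhibition. Compound 1 `Cc1nc(-c2c[nH]c3ccccc23)co1` gives 103000 nM. Compound 2 `c1ccc2c(-c3coc(C4CCNCC4)n3)c[nH]c2c1` gives 528000 nM. Among the compounds with values here, the one measured step, a 5.1-fold higher number from compound 1 to compound 2 (0.71 log units; beyond the scatter), is piperidin-4-yl in place of methyl on an aromatic carbon. On these two numbers compound 2 stands highest, its nearest neighbour being compound 1 with the lower number, the gap beyond the scatter.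

Compound 3 `Cn1cc(-c2coc(C3CCNCC3)n2)c2ccccc21` differs from compound 2 by methyl in place of hydrogen on an aromatic nitrogen. Within the data shown here, no measured step touches this place: the single known step concerns the aromatic carbon substituent, not the ring nitrogen, so it does not bear on the change from compound 2 to compound 3 and gives no direction. With nothing in the data pointing either way, the expected step in this assay is none beyond the scatter, a 1.1-fold lower number from compound 2 to compound 3 (0.02 log units; within the scatter), and compound 3 is expected to stay close to compound 2. The estimate for compound 3 is 500000 nM, within 200000 nM to 1500000 nM.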

Compound 3, half-maximal inhibitory concentration: 103000 nM
Compound 3: the middle estimate sits 4.9-fold (0.69 log units) above what was measured; measured number below the stated range.
By their numbers in this assay, from the lowest: compounds 1 and 3 (each within the scatter of the next); then compound 2.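

Methyl in place of hydrogen on the aromatic nitrogen gives in this assay a 5.1-fold lower number from compound 2 to compound 3 (0.71 log units; beyond the scatter) as a step beyond the scatter, so this ring nitrogen is a place where the number responds, which the earlier step on the aromatic carbon could not show. The hydrogen on this nitrogen is therefore not required for activity in this pair, since compound 3, which carries methyl there, has the lower number of the two. No measurement at hand bears on the reason for this step.

On these data alone, whether the lower number is particular to methyl remains open, and an ethyl group, a longer chain or an acetyl group on the same nitrogen would test how much the place tolerates. As far as these compounds go, it is also open whether the step carries over to the methyl-bearing carbon substituent of compound 1, or holds only with piperidin-4-yl on the aromatic carbon.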